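The compounds below may be only part of what the source reports. "The series", "measured", "known", "first", "only" and "open" are said of these compounds alone.

Measured so far in an assay for inhibition of Fatty-acid amide hydrolase 1 (Rattus norvegicus); a higher number here means a weaker inhibitor, a lower number a stronger inhibitor:
compound 1 `NC(=O)c1ccc(-c2cnc(C(O)CCc3ccc(-c4ccccc4)cc3)o2)nc1`: > 1000 nM, a limit of the assay
compound 2 `O=C(O)c1ccc(-c2cnc(CCCc3ccc(-c4ccccc4)cc3)o2)nc1`: 20000 nM
compound 3 `COC(=O)c1ccc(-c2cnc(CCCc3ccc(-c4ccccc4)cc3)o2)nc1`: 50000 nM

Compound 1 reports only a limit, (the limit of > 1000 nM in this assay, at which 1 of the 3 values shown sits). Among the measured compounds shown here, of the two numbers, compound 3 holds the higher one; the single one-point step, a 2.5-fold higher number from compound 2 to compound 3 (0.40 log units; beyond the scatter), places compound 2 beneath it by a modest margin. Compound 4 `NC(=O)c1ccc(-c2cnc(CCCc3ccc(-c4ccccc4)cc3)o2)nc1` differs from compound 3 by amino in place of methoxy on a carbonyl carbon. For the measured compounds named here, no measured step covers this exact change; the nearest comparison, also at the carbonyl carbon, is the modest step of a 2.5-fold higher number from compound 2 to compound 3 (0.40 log units; beyond the scatter). Compound 1 also carries a carbamoyl group but gives only a limit. The expected step is a 2.5-fold lower number from compound 3 to compound 4 (0.40 log units; beyond the scatter), toward a somewhat lower number. For compound 4 the estimate in this assay is 20000 nM, with a range of 5000 nM to 80000 nM.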

Compound 4, inhibition constant: 30000 nM
Beside the measured number, compound 4's estimate is 1.5-fold (0.18 log units) below it; the range from low to high includes it.
By their numbers in this assay, from the lowest: compounds 2, 4 and 3 (each within the scatter of the next, the first and the last beyond it).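

At the carbonyl carbon, amino in place of methoxy gives a 1.7-fold lower number from compound 3 to compound 4 (0.22 log units; within the scatter) in this assay, and amino in place of hydroxy gives a 1.5-fold higher number from compound 2 to compound 4 (0.18 log units; within the scatter). Compound 4 therefore cannot be separated from either compound 2 or compound 3, although those two lie beyond the scatter of each other. Compound 1 gives only a limit, so its step cannot be read: the limit of > 1000 nM in this assay, at which 1 of the 4 values shown sits.

As far as these compounds go, whether any group on this carbonyl carbon moves the number far from these values stays open. A dimethylamino group there, or a nitrile in place of the whole carbamoyl group, would test this.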